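The source may report more compounds than this note shows. Statements on the series, on what has been measured and on what is new or still open speak of the compounds shown alone.

Measured compounds in a functional assay on CEM-DNR-bulk cells (Homo sapiens), read by MTT assay, with a stated time of 72 h; a lower number here means a stronger inhibitor, a higher number a weaker inhibitor:

- compound 1, `Nc1nc(N)c2c(-c3ccsc3)cn([C@@H]3O[C@H](CO)[C@@H](O)[C@H]3O)c2n1`: compound 1 gives > 20000 nM, a limit of the assay.
- compound 2, `O=c1[nH]cnc2c1c(-c1ccsc1)cn2[C@@H]1O[C@H](CO)[C@@H](O)[C@H]1O`: compound 2 gives > 20000 nM, a limit of the assay.
- compound 3, `Nc1nc2c(c(-c3ccsc3)cn2[C@@H]2O[C@H](CO)[C@@H](O)[C@H]2O)c(=O)[nH]1`: compound 3 gives > 20000 nM, a limit of the assay.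

Compound 2 stands at a limit only; no number is known for it, and the two other values shown are limits as well. Within the data shown here, the single change between measured compounds, a step that the two limits leave unreadable from compound 2 to compound 3, cannot be sized, since both ends sit at the limit. the limit of > 20000 nM in this assay, at which 3 of the 3 values shown sit, is all the evidence there is on this series.

Compound 4, `O=c1[nH]cnc2c1c(-c1ccccc1)cn2[C@@H]1O[C@H](CO)[C@@H](O)[C@H]1O`, is not yet measured. It differs from compound 2 by phenyl in place of thiophen-3-yl on an aromatic carbon. Among the measured compounds shown here, no measured step touches this exchange, so nothing here says whether it moves the number at all. The one thing the data show is that every measured member of the shared core sits at the limit, and compound 4 keeps that core unchanged. Compound 4 is therefore expected to stay at or near the limit, with an estimated step that the limit leaves unreadable from compound 2 to compound 4. The estimate for compound 4 is 30000 nM, between 10000 nM and 100000 nM, with a limit the most likely report.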

Compound 4, half-maximal inhibitory concentration: > 20000 nM
Compound 4 gave a limit, no number; the forecaster's own chance of this, stated with the estimate: 85%; the middle value does not contradict the limit.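

In this assay compound 4 gives > 20000 nM, a limit of the assay. Compound 2 also stands at a limit, so the exchange of thiophen-3-yl for phenyl from compound 2 to compound 4 yields no readable step. The compounds shown leave open whether any change to the shared core would give a measurable value: the limit of > 20000 nM in this assay, at which 4 of the 4 values shown sit.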